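The compounds below may be only part of what the source reports. "The series", "measured", "known", "first", "only" and "open" are said of these compounds alone.

Three related compounds have been examined in a functional assay on BT-549 cells (Homo sapiens) for cytotoxicity, read by sulforhodamine B assay, with a stated time of 48 h; on this read-out lower numbers stand for higher toxicity in this test and higher numbers for lower toxicity in this test. Compound 1 `ClCc1ccccc1Cn1cnc2c(Cl)nc(Cl)nc21` gives 4160 nM in this assay. Compound 2 `ClCc1ccccc1Cn1cnc2ncnc(Cl)c21` gives 25100 nM in this assay, and compound 3 `Nc1nc(Cl)c2ncn(Cc3cccc(CCl)c3)c2n1` gives 58900 nM in this assay. Compound 2 thus stands second highest of the three numbers: its nearest neighbour is compound 3, with a higher number that lies beyond the scatter, while compound 1 sits furthest away, with a lower number that also lies beyond the scatter.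

Compound 4 `ClCc1ccccc1Cn1cnc2nc(Cl)nc(Cl)c21` has not yet been measured in this assay. It differs from compound 2 by chloro in place of hydrogen on an aromatic carbon, the carbon in question lying between two ring nitrogen atoms, meta to a chloro group, meta to a fused ring and para to a fused ring. Within the data shown here, no step of this kind has been measured among the compounds at hand, so the expectation rests only on the spread of the three numbers. Compound 1, which carries two chloro groups on its core, gives 4160 nM, and this is the only hint that a second chloro might go with a lower number. The step from compound 2 to compound 4 is therefore expected to be a modest fall, of about a 2.8-fold lower number from compound 2 to compound 4 (0.45 log units; beyond the scatter), and compound 4 is estimated at 9000 nM, within a range from 3000 nM to 30000 nM.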

Compound 4, concentration lethal to 50% of the cells: 7070 nM
Estimate against measurement, compound 4: 1.3-fold (0.10 log units) above; the measured number falls inside the stated range.
By their numbers in this assay, from the lowest: compounds 1 and 4 (each within the scatter of the next); then compound 2; then compound 3.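

In this assay, among these compounds, chloro in place of hydrogen on the aromatic carbon between two ring nitrogen atoms gives a 3.6-fold lower number from compound 2 to compound 4 (0.55 log units; beyond the scatter), the first step here that can be read from a pair differing in one place. Among the compounds shown here, it shows that this position is not indifferent to substitution: with chloro there, the number moves towards higher toxicity in this test, where the earlier compounds offered no such pair. Nothing at hand accounts for the size of this step.

The compounds shown leave open whether a fluoro, a methoxy or a methyl group on this same carbon would move the number in the same direction or by a similar amount. For the compounds shown here, they also leave open whether the chloro step would keep its size with a change elsewhere in the molecule, since this single pair is the only reading of it.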